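The compounds below may be only part of what the source reports. "The series", "measured", "known", "first", "only" and "open" are said of these compounds alone.

Compound 1 `Cc1n[nH]c2ccc(-c3nc4cnc(N5CCN(C)CC5)cn4c3Nc3ccc(I)cc3)cc12` and compound 2 `Cc1n[nH]c2ccc(-c3nc4cnc(N5CCN(C)CC5)cn4c3Nc3ccccc3)cc12` share the same core and differ only in the ring carried on the nitrogen. In a functional assay on MV4-11 cells (Homo sapiens) for inhibition, with a stated time of 120 h, tested at 10 uM (on this read-out higher numbers stand for more inhibition at the one concentration tested (going by the name of the read-out) and lower numbers for less inhibition), compound 1 gives 0%. In this assay compound 2 gives 0%. The step of no change at the digits printed from compound 1 to compound 2 (within the scatter) shows that replacing iodo with hydrogen on that ring made no difference within the scatter, so compound 2 stands level with compound 1 at the digits reported, with no sign of inhibition for either.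

Compound 3 `Cc1n[nH]c2ccc(-c3nc4cnc(N5CCN(C)CC5)cn4c3Nc3ccc(F)c(Cl)c3)cc12` has not yet been measured in this assay. It differs from compound 2 in that (3-chloro-4-fluorophenyl in place of phenyl on a nitrogen on an aromatic ring). For the measured compounds named here, the only measured step that bears on this change is no change at the digits printed from compound 1 to compound 2 (within the scatter), in which a halogen on the same ring came and went without any change beyond the scatter. Adding two halogens to the ring is a different change, and no measured pair shows its effect directly, so the expectation rests on the absence of any movement so far. For compound 3 the expected step is a number 3 percentage points higher from compound 2 to compound 3 (within the scatter), nothing beyond the scatter. The estimate for compound 3 is 3%, within a range from -10% to 25%.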

Compound 3, a percentage reported as inhibition, at one concentration (the size of the read-out at that concentration, not a potency): 84.1%
Estimate against measurement, compound 3: 81.1 percentage points below; measured number above the stated range.
By their numbers in this assay, from the lowest: compounds 1 and 2 (each within the scatter of the next); then compound 3.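

Compounds 1 and 2 had suggested that the ring on the nitrogen could change without effect, but that held only for the two rings tested. In this assay, 3-chloro-4-fluorophenyl in place of phenyl gives a number 84.1 percentage points higher from compound 2 to compound 3 (beyond the scatter), and in place of 4-iodophenyl it gives a number 84.1 percentage points higher from compound 1 to compound 3 (beyond the scatter), so this position can govern the read-out almost entirely. Carrying a halogen on this ring is also not enough in itself, as compound 1 bears iodo and gives 0%, and no measurement offered here accounts for the rise.

The chloro and fluoro groups enter together, so the compounds shown cannot tell whether one of them, or only the pair, is needed; rings with 3-chlorophenyl or 4-fluorophenyl alone would separate the two, and a non-halogen group such as methoxy or nitrile on the ring would show whether halogens are required at all. Going by these compounds, the read-out also comes from a single concentration, so how potent compound 3 is remains open, as does whether the same ring would have this effect on a different core.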